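An Isobutyl Branch on a Fused Lactam Core

The source may hold more compounds than are shown below. What is called first, only, known or untested is meant among the compounds shown, and "the series" means these compounds.

Compound 2 `O=C1Nc2ccccc2C1CCCCN1CCN(c2cccc(Cl)c2)CC1` carries the shared core with hydrogen on the saturated ring carbon. In a functional assay on the whole organism (strain NMRI) with Mus musculus as the target, with a stated time of 5 min (on this read-out higher numbers stand for an effect only at larger amounts of compound and lower numbers for an effect already at smaller amounts), compound 2 reaches only a limit, > 10 mg/kg, and not a number. Its companions stand without a result: compound 1 `O=C1Nc2ccc(F)cc2C1CCCCN1CCN(c2cccc(Cl)c2)CC1` is recorded in this assay as "not determined" (no result reported), and compound 3 `CCC1(CCCCN2CCN(c3cccc(OC)c3)CC2)C(=O)Nc2ccccc21` likewise as "not determined" (no result reported). Among the measured compounds shown here, the only evidence in hand is therefore (the limit of > 10 mg/kg in this assay, at which 1 of the 3 values shown sits). Compound 4 `CC(C)CC1(CCCCN2CCN(c3cccc(Cl)c3)CC2)C(=O)Nc2ccccc21` differs from compound 2 by isobutyl in place of hydrogen on a saturated ring carbon. For the measured compounds named here, with no measured step to guide the size of this change, the expected movement is none beyond the scatter, an estimated step of a number no higher from compound 2 to compound 4 (the limit leaves the size open). Compound 4 is estimated to give 10 mg/kg in this assay, within a range from 3 mg/kg to 30 mg/kg.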

Compound 4, minimum effective dose: > 10 mg/kg
Compound 4: only a limit was reported; the forecaster's own chance of this, stated with the estimate: 50%; the middle value sits exactly at the limit.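

No step can be read between compound 2 and compound 4, since each stands only at a limit: the limit of > 10 mg/kg in this assay, at which 2 of the 4 values shown sit.

The compounds shown leave open how far, if at all, isobutyl in place of hydrogen on a saturated ring carbon moves the result in this assay.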